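A few compounds are considered here, and "the series" means these few. Any claim that something is new, unique, unknown or untested is made for them only; others in the source may bear on it.

Measured compounds and their results in a functional assay on ACHN cells (Homo sapiens) for cytotoxicity, read by sulforhodamine B assay, with a stated time of 72 h; on this read-out lower numbers stand for stronger inhibition of growth and higher numbers for weaker inhibition of growth:
Compound 1, `O=C(Nc1ccccc1O)C1CCc2ccccc2N1C(=O)c1ccccc1Cl`: 44200 nM
Compound 2, `CCCCCCCCC(=O)N1c2ccccc2CCC1C(=O)Nc1ccccc1O`: 65000 nM

Compound 2 and compound 1 lie within the scatter of each other, as the step of a 1.5-fold higher number from compound 1 to compound 2 (0.17 log units; within the scatter) shows, so neither can be called the weaker of the pair. Compound 3, `O=C(Nc1ccccc1O)C1CCc2ccccc2N1C(=O)c1ccccc1`, has not yet been tested in this assay. It differs from compound 2 in one place: phenyl in place of octyl on a carbonyl carbon. Within the data shown here, only one measured step bears on a change at this carbonyl carbon, whose other neighbour is an amide-type nitrogen in a ring: the step of a 1.5-fold higher number from compound 1 to compound 2 (0.17 log units; within the scatter) exchanged a 2-chlorophenyl for the octyl and stayed within the scatter. Compound 3 carries a phenyl there, as compound 1 carries a 2-chlorophenyl; a direct step from 2-chlorophenyl to phenyl has not been measured. On this basis the expected step from compound 2 to compound 3 is a 1.3-fold lower number from compound 2 to compound 3 (0.11 log units; within the scatter), with no change beyond the scatter expected in either direction. Compound 3 is therefore estimated to give about 50000 nM in this assay, within a range from 20000 nM to 120000 nM.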

Compound 3, concentration for 50% growth inhibition: 4260 nM
Estimate against measurement, compound 3: 12-fold (1.07 log units) above; the measured number lies below the stated range.
By their numbers in this assay, from the lowest: compound 3; then compounds 1 and 2 (each within the scatter of the next).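

At this carbonyl carbon, whose other neighbour is an amide-type nitrogen in a ring, the earlier pair had shown no separation, but in this assay the change from octylcarbonyl to benzoyl gives a 15-fold lower number from compound 2 to compound 3 (1.18 log units; beyond the scatter) and so shows that the group here can matter strongly. An aromatic ring at this place is not enough on its own, as compound 1 also carries one and lies within the scatter of compound 2, while hydrogen in place of chloro on an aromatic carbon gives a 10-fold lower number from compound 1 to compound 3 (1.02 log units; beyond the scatter) and makes this single substitution on the phenyl as decisive as the exchange of the octyl. Nothing available explains why either step is so large.

The compounds shown leave open whether the loss in compound 1 belongs to chloro in particular or would also follow from another group on that aromatic carbon, such as fluoro, methyl or methoxy. They also leave open whether the ring must be aromatic at all, which cyclohexyl in place of phenyl would test, and how a shorter chain would compare with the octyl.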